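Cytotoxicity limits across three amide variants and one proposal

The source may report more compounds than this note shows. Statements on the series, on what has been measured and on what is new or still open speak of the compounds shown alone.

Compound 1 `COCCNC(=O)/C=C/c1cnc(Nc2ccc(C#N)cc2)nc1Oc1c(C)cc(C#N)cc1C` — in an ADME assay on TZM cells (Homo sapiens) for cytotoxicity, with a stated time of 1 days (on this read-out higher numbers stand for lower toxicity in this test and lower numbers for higher toxicity in this test), compound 1 gives > 213 nM, a limit.
Compound 2 `Cc1cc(C#N)cc(C)c1Oc1nc(Nc2ccc(C#N)cc2)ncc1/C=C/C(=O)NCCOCCO` — in this assay compound 2 gives > 200 nM, a limit.
Compound 3 `CC(=O)N1CCN(C(=O)/C=C/c2cnc(Nc3ccc(C#N)cc3)nc2Oc2c(C)cc(C#N)cc2C)CC1` — in this assay compound 3 gives > 192 nM, a limit.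

Compound 2 thus stands at a limit only, and the two other values are limits as well (the limit of > 192 nM in this assay, at which 1 of the 3 values shown sits, (the limit of > 200 nM in this assay, at which 1 of the 3 values shown sits), (the limit of > 213 nM in this assay, at which 1 of the 3 values shown sits)). Compound 4 `Cc1cc(C#N)cc(C)c1Oc1nc(Nc2ccc(C#N)cc2)ncc1/C=C/C(=O)NCCN1CCN(S(C)(=O)=O)CC1` differs from compound 2 by 4-(methylsulfonyl)piperazin-1-yl in place of 2-hydroxyethoxy on a saturated chain carbon, two bonds along the chain from an amide-type nitrogen. The measured steps that bear on this, a step that the two limits leave unreadable from compound 1 to compound 2, a step that the two limits leave unreadable from compound 1 to compound 3 and a step that the two limits leave unreadable from compound 2 to compound 3, all run between limits and give no readable size. For compound 4 the expected step is a step that the limit leaves unreadable from compound 2 to compound 4, again unreadable, so compound 4 is expected to be reported as a limit once more. Compound 4 is estimated at 250 nM, range 150 nM to 600 nM.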

Compound 4, half-maximal cytotoxic concentration: > 166 nM
Compound 4 ended at the assay's limit; the forecaster's own chance of this, stated with the estimate: 85%; the middle value lies beyond the limit too.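

Compound 4 again gives only a limit, so its steps from compound 1 and from compound 2 cannot be read. The compounds shown leave open where any of these amides actually falls in this assay, and whether these amide changes shift the read-out at all.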